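The source may hold more compounds than are shown below. What is called first, only, known or untested is meant among the compounds shown, and "the series" means these compounds.

Working notes on the series, read in a functional assay on the whole organism with Mus musculus as the target, in the rotarod test; a lower number here means that less compound is needed, a higher number that more compound is needed for the effect. Compound 1 `Cc1cccc2c1CC/C2=C\C(=O)NC1CC1` gives 64 mg/kg. Compound 2 `CN(C)C(=O)/C=C1\CCc2c(F)cc(F)cc21` gives 100 mg/kg, and compound 3 `NC(=O)/C=C1/CCc2ccc(F)cc21` gives 92 mg/kg. Compound 1 therefore stands within the usual scatter of both other compounds, and the three numbers cannot be ranked. Among the compounds with values here, no two measured compounds differ in one place only, so the series offers no direct measure of a single change.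

Compound 4 `O=C(/C=C1\CCc2ccccc21)NC1CC1` has not yet been measured. Its difference from compound 1 is hydrogen in place of methyl on an aromatic carbon. The data give no separate reading of this change. Within the data shown here, the only guide is the narrow spread of the series, with compound 2 at 100 mg/kg and compound 3 at 92 mg/kg both within the scatter of compound 1 at 64 mg/kg. No shift beyond the scatter is therefore expected in this assay. The expected step, a 1.2-fold higher number from compound 1 to compound 4 (0.07 log units; within the scatter), lies within the scatter. For compound 4 the estimated value is 75 mg/kg, with an expected range of 38 mg/kg to 140 mg/kg.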

Compound 4, dose for half-maximal effect: 235 mg/kg
Compound 4: middle estimate off by 3.1-fold (0.50 log units), on the low side, outside the stated range (above it).
By their numbers in this assay, from the lowest: compounds 1, 3 and 2 (each within the scatter of the next); then compound 4.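

In this assay, within the data shown here, the methyl on the aromatic carbon, ortho to a fused ring and meta to a fused ring, gives the first reading of a single change: hydrogen in place of methyl gives a 3.7-fold higher number from compound 1 to compound 4 (0.56 log units; beyond the scatter) on an otherwise unchanged structure. This position therefore matters to the read-out, which the narrow spread of the first compounds, none differing from another in one place only, could not show. Nothing in hand bears on why removing this one carbon has this effect.

Whether the step is specific to methyl remains open, since the compounds shown do not tell how an ethyl, a methoxy or a chlorine on the same carbon would read. Also open, going by these compounds, is whether the same change would give a similar step with the other amides, such as the dimethyl amide or the unsubstituted amide.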